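Removing the methoxycarbonyl from compound 1

A few compounds are considered here, and "the series" means these few. Any claim that something is new, unique, unknown or untested is made for them only; others in the source may bear on it.

Measured so far in a functional assay (brain) for inhibition, with Rattus norvegicus as the target; a lower number here means a stronger inhibitor, a higher number a weaker inhibitor:
compound 1 `COC(=O)NC1=NC(c2c(Cl)cccc2Cl)CN1` gives > 100000 nM as a limit of the assay
compound 2 `CCOC(=O)NC1=NC(c2ccccc2Cl)CN1C` gives 30000 nM as a number

Within the data shown here, on the numbers so far, compound 1 has no exact position: it sits at the limit of > 100000 nM in this assay, at which 1 of the 2 values shown sits, and has no number of its own. Among the measured compounds shown here, compound 2 is the only compound with a number.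

Compound 3 `NC1=NC(c2c(Cl)cccc2Cl)CN1` is still unmeasured. The change from compound 1 is hydrogen in place of methoxycarbonyl on an amine nitrogen and amounts to hydrogen in place of methoxycarbonyl on an amine nitrogen, or (methoxycarbonyl)amino to amino. For the measured compounds named here, no measured step is available to size this change, so the expectation is loose. A move towards stronger inhibition in this assay is expected, with an at least 20-fold lower number from compound 1 to compound 3 (1.30 log units; beyond the scatter) as the estimated size of the step. The estimated value for compound 3 is 5000 nM with an expected range from 500 nM to 60000 nM in this read-out.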

Compound 3, half-maximal inhibitory concentration: 100 nM
Estimate against measurement, compound 3: 50-fold (1.70 log units) above, outside the stated range (below it).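

Hydrogen in place of methoxycarbonyl on an amine nitrogen gives an at least 1000-fold lower number from compound 1 to compound 3 (3.00 log units; beyond the scatter) in this assay, so the group on this nitrogen has a large effect on the read-out, which compounds 1 and 2 alone could not show. Compound 3, at 100 nM, is the only compound shown with a free amino group, whereas the other two both carry an alkoxycarbonyl group on that nitrogen. The step has only a minimum size, as compound 1 stands at a limit and not at a number: the limit of > 100000 nM in this assay, at which 1 of the 3 values shown sits.

The compounds shown leave open whether any small group on this nitrogen, such as methyl or acetyl, keeps the value of compound 3 or whether only hydrogen does. Among these compounds, it also remains open how far the step depends on the rest of the molecule, as no matched pair exists with the substituents of compound 2.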